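The compounds below may be only part of what the source reports. "The series", "measured", "known", "first", "only" and "open" are said of these compounds alone.

Three compounds that share one core have numbers in a functional assay on the whole organism with Rattus norvegicus as the target; a higher number here means that more compound is needed for the effect, a lower number that less compound is needed. Compound 1 (`COc1cc(C)nc(OC)c1NC(=O)N(Cc1ccc(Oc2ccc(F)cc2)cc1)C1CCCCCC1`) gives 0.032 mg/kg, and compound 2 (`CSc1cc(C)nc(Cl)c1NC(=O)N(Cc1ccc(Oc2ccc(F)cc2)cc1)C1CCCCCC1`) gives 0.022 mg/kg. Compound 3 (`Cc1cc(S(C)(=O)=O)c(NC(=O)N(Cc2ccc(Oc3ccc(F)cc3)cc2)C2CCCCCC2)c(S(C)(=O)=O)n1`) gives 0.068 mg/kg, the highest number of the three and beyond the scatter from compound 1. Compound 1 therefore sits with compound 2, within the scatter of it, and well clear of compound 3.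

Compound 4 (`COc1nc(C)ccc1NC(=O)N(Cc1ccc(Oc2ccc(F)cc2)cc1)C1CCCCCC1`) differs from compound 1 by hydrogen in place of methoxy on an aromatic carbon, ortho to a large group. For the measured compounds named here, the one measured step that bears on this is a 1.5-fold lower number from compound 1 to compound 2 (0.16 log units; within the scatter), which exchanges groups on the same six-membered aromatic ring and stays within the scatter. Compound 3, at 0.068 mg/kg, also keeps a group on that carbon. Going by the values given here, no measured compound has hydrogen there, so the data offer no direct test. Losing a group outright is a bigger departure than exchanging one, so a modest move to a higher number is expected in this assay, with real uncertainty. The estimated step is a 3.1-fold higher number from compound 1 to compound 4 (0.49 log units; beyond the scatter). For compound 4 the estimated value is 0.1 mg/kg, with an expected range from 0.03 mg/kg to 0.4 mg/kg.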

Compound 4, dose for half-maximal effect: > 0.1 mg/kg
Compound 4 gave a limit, no number (the forecaster's own chance of this, stated with the estimate: 10%); the middle value sits exactly at the limit.
By their numbers in this assay, from the lowest: compounds 2 and 1 (each within the scatter of the next); then compound 3. At a limit, above all of these: compound 4.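

In this assay compound 4 gives a limit, not a number: the limit of > 0.1 mg/kg in this assay, at which 1 of the 4 values shown sits.

Compounds 1, 2 and 3 all carry a group on this aromatic carbon, ortho to a large group, so they could not show what happens when it stands empty; with hydrogen in place of methoxy there is an at least 3.1-fold higher number from compound 1 to compound 4 (0.49 log units; beyond the scatter), a change that clears the usual scatter, unlike the exchange of groups between compound 1 and compound 2. The comparison with the other close compound points the same way, with an at least 4.5-fold higher number from compound 2 to compound 4 (0.65 log units; beyond the scatter), and both steps give only the smallest size the change can have, so the true loss may be larger.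

The compounds shown leave open how far past its limit compound 4 really lies, and so how large the penalty for having hydrogen on this carbon is. On these data alone, it also stays open whether a single fluorine atom, an amine or an ethoxy group on this carbon, with the rest of compound 1 unchanged, would bring the dose back down to the level of compound 1.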